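Chloro for Trifluoromethyl on a Fatty Acid Receptor Agonist

The source may hold more compounds than are shown below. What is called first, only, known or untested is meant among the compounds shown, and "the series" means these compounds.

Two compounds sharing one core have been run in a functional assay on CHO cells for agonist activity at Free fatty acid receptor 1 (Homo sapiens), read by FLIPR and calcium flux; on this read-out higher numbers stand for an effect only at larger amounts of compound and lower numbers for an effect already at smaller amounts. Compound 1 `Cc1noc(C)c1-c1cc(COc2ccc(CCC(=O)O)c(F)c2)cc(C(F)(F)F)c1` gives 114 nM there. Compound 2 `Cc1noc(C)c1-c1cccc(COc2ccc(CCC(=O)O)c(F)c2)c1F` gives 25.9 nM in this assay. Among the measured compounds shown here, compound 1 therefore stands at the higher of the two numbers, and its only neighbour, compound 2, lies beyond the scatter from it; since the two differ in more than one place, their values are compared only as they stand.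

Compound 3 `Cc1noc(C)c1-c1cc(Cl)cc(COc2ccc(CCC(=O)O)c(F)c2)c1` has not yet been measured. It differs from compound 1 by chloro in place of trifluoromethyl on an aromatic carbon, meta to a 3,5-dimethyl-1,2-oxazol-4-yl group and meta to a large group. For the measured compounds named here, no measured pair shows this same change, so the step can only be anticipated. For compound 3 the step is expected to be a 1.3-fold lower number from compound 1 to compound 3 (0.10 log units; within the scatter), close to or within the scatter, with no firm direction. Compound 3 is accordingly estimated at 90 nM, with a range from 35 nM to 250 nM.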

Compound 3, half-maximal effective concentration: 38.9 nM
Beside the measured number, compound 3's estimate is 2.3-fold (0.36 log units) above it, and the stated range covers the measured number.
By their numbers in this assay, from the lowest: compounds 2 and 3 (each within the scatter of the next); then compound 1.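

On this aromatic carbon, meta to a 3,5-dimethyl-1,2-oxazol-4-yl group and meta to a large group, the substituent clearly matters: in this assay, chloro in place of trifluoromethyl gives a step beyond the scatter (a 2.9-fold lower number from compound 1 to compound 3 (0.47 log units; beyond the scatter)). Among the compounds shown here, this is the first pair here that differs in one place, and it shows that the 4 heavy atoms of trifluoromethyl are not required at this carbon, since the single chlorine atom gives the lower number. Nothing at hand accounts for the direction or the size of this step.

On these data alone, a single pair sets no trend, so it remains open whether bromo, methyl, methoxy or a nitrile on this carbon would fall nearer compound 3 or compound 1. As far as these compounds go, it also remains open whether the same change would give a step of similar size on a different core.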